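Adenosine amides with benzyl groups: survey before compound 4

The source may hold more compounds than are shown below. What is called first, only, known or untested is meant among the compounds shown, and "the series" means these compounds.

Compound 1 `OC[C@H]1O[C@@H](n2cnc3c(NCc4cccc(F)c4)ncnc32)[C@H](O)[C@@H]1O`; in a functional assay on HOS cells (Homo sapiens) for antiproliferative activity, with a stated time of 72 h (a lower number here means a stronger inhibitor, a higher number a weaker inhibitor), compound 1 gives > 166000 nM, a limit of the assay.
Compound 2 `COc1cccc(CNc2ncnc3c2ncn3[C@@H]2O[C@H](CO)[C@@H](O)[C@H]2O)c1`; in this assay compound 2 gives > 166000 nM, also a limit of the assay.
Compound 3 `COc1cc(CNc2ncnc3c2ncn3[C@@H]2O[C@H](CO)[C@@H](O)[C@H]2O)cc(OC)c1`; in this assay compound 3 gives "not determined" (no result reported), so no result was reported for compound 3.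

Among the measured compounds shown here, compound 3 therefore stands nowhere on the numbers: both measured neighbours sit at the limit of > 166000 nM in this assay, at which 2 of the 3 values shown sit, and the only step, a step that the two limits leave unreadable from compound 1 to compound 2, cannot be read. Compound 4 `OC[C@H]1O[C@@H](n2cnc3c(NCc4ccccc4OC(F)F)ncnc32)[C@H](O)[C@@H]1O` differs from compound 3 as follows: 2-(difluoromethoxy)phenyl in place of 3,5-dimethoxyphenyl on a saturated chain carbon bound to a nitrogen on an aromatic ring. For the measured compounds named here, no measured step bears on this change, so no direction can be expected in this assay beyond the scatter. For compound 4 in this assay an estimate of 166000 nM, between 50000 nM and 500000 nM, is expected, most probably reported again only as a limit.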

Compound 4, half-maximal inhibitory concentration: > 166000 nM
Compound 4: only a limit was reported; the forecaster's own chance of this, stated with the estimate: 85%; the middle value lies on the limit itself.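

In this assay compound 4 gives > 166000 nM, a limit of the assay. The steps to compound 4 from compound 1 and compound 2 cannot be read, with limits at both ends. Left open is what number lies behind each limit, and where compound 3 stands.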